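Phenyl for Thiophene on a Fused Core

The source may report more compounds than this note shows. Statements on the series, on what has been measured and on what is new or still open speak of the compounds shown alone.

Compound 1 `Nc1c(C(=O)N/N=C/c2ccccc2)oc2nc(-c3ccccc3)cc(C(F)(F)F)c12`: 13100 nM
Compound 2 `CCCNC(=O)c1oc2nc(-c3cccs3)cc(C(F)(F)F)c2c1N`: 17200 nM

Both compounds were tested in a functional assay on HepG2 cells (Homo sapiens) for antiproliferative activity, read by MTT assay; a lower number here means a stronger inhibitor, a higher number a weaker inhibitor. Compound 2 shows the higher of the two numbers, yet compound 1 lies within the usual scatter of it, so the two cannot be told apart. Compound 3 `CCCNC(=O)c1oc2nc(-c3ccccc3)cc(C(F)(F)F)c2c1N` differs from compound 2 in one place: phenyl in place of thiophen-2-yl on an aromatic carbon. Among the measured compounds shown here, no measured pair shows this exchange on its own, so the size of the step is unknown from the data; it is expected to be small, within the scatter, in neither direction. Compound 3 is expected to give about 14000 nM, with a range from 7000 nM to 28000 nM. The step of a 1.2-fold lower number from compound 2 to compound 3 (0.09 log units; within the scatter) is estimated to stay within the scatter.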

Compound 3, half-maximal inhibitory concentration: 37400 nM
For compound 3 the middle estimate is 2.7-fold (0.43 log units) below the measured one; the measured number lies above the stated range.
By their numbers in this assay, from the lowest: compounds 1 and 2 (each within the scatter of the next); then compound 3.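

Phenyl in place of thiophen-2-yl gives a 2.2-fold higher number from compound 2 to compound 3 (0.34 log units; beyond the scatter) in this assay, so the ring on this aromatic carbon, next to the ring nitrogen, does affect the result, and phenyl is the weaker of the two. With phenyl held constant, a group of 3 heavy atoms in place of a group of 8 heavy atoms on the amide-type nitrogen gives a 2.9-fold higher number from compound 1 to compound 3 (0.46 log units; beyond the scatter), so that site matters too. Nothing measured here explains either step. Still open, going by these compounds, is how a furan-2-yl or 4-fluorophenyl ring would behave on this carbon, and how a longer chain or an amine would behave on the amide-type nitrogen.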